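The source may hold more compounds than are shown below. What is called first, only, known or untested is meant among the compounds shown, and "the series" means these compounds.

In an assay on HEK293 cells for inhibition of Steryl-sulfatase (Homo sapiens), tested at 0.1 uM (on this read-out higher numbers stand for a stronger effect at the one concentration tested and lower numbers for a weaker effect), compound 1 `CN(C)CCN(CCN(C)C)c1cccc(C(=O)N2CCc3ccc(OS(N)(=O)=O)cc3C2)c1` gives 0%, compound 2 `NS(=O)(=O)Oc1ccc2c(c1)CN(C(=O)c1cccc(N3CCc4ccccc4C3)c1)CC2` gives 24.1%, and compound 3 `CCCN(Cc1ccccc1)c1cccc(C(=O)N2CCc3ccc(OS(N)(=O)=O)cc3C2)c1` gives 23.1%.

Compound 3 thus stands second of the three numbers: the nearest step is a number 1 percentage points lower from compound 2 to compound 3 (within the scatter), while the furthest step is a number 23.1 percentage points higher from compound 1 to compound 3 (beyond the scatter). Compound 4 `CCN(Cc1ccncc1)c1cccc(C(=O)N2CCc3ccc(OS(N)(=O)=O)cc3C2)c1` differs from compound 3 by ethyl((pyridin-4-yl)methyl)amino in place of benzyl(propyl)amino on an aromatic carbon.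

The step that bears most directly on this change is a number 1 percentage points lower from compound 2 to compound 3 (within the scatter), where exchanging one amine bearing an aromatic ring for another left the read-out essentially unchanged. By contrast a number 24.1 percentage points higher from compound 1 to compound 2 (beyond the scatter) and a number 23.1 percentage points higher from compound 1 to compound 3 (beyond the scatter) show that the compound carrying two dimethylamino chains sits far lower. Compound 4 again carries an amine with an aromatic ring, so a step of about a number 5.1 percentage points lower from compound 3 to compound 4 (within the scatter) is expected, within the scatter. Compound 4 is estimated at 18%, between 4% and 34%.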

Compound 4, a percentage reported as inhibition, at one concentration (the size of the read-out at that concentration, not a potency): 33.3%
The estimate for compound 4 lay 15.3 percentage points below the measured number, and the stated range covers the measured number.
By their numbers in this assay, from the lowest: compound 1; then compounds 3, 2 and 4 (each within the scatter of the next, the first and the last beyond it).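

Replacing benzyl(propyl)amino with ethyl((pyridin-4-yl)methyl)amino gives a number 10.2 percentage points higher from compound 3 to compound 4 (beyond the scatter) and shows that this position can respond to a change between two amines that both carry an aromatic ring. That response has limits, since the comparison with the fused amine gives a number 9.2 percentage points higher from compound 2 to compound 4 (within the scatter) and leaves those two compounds level. The gap to the amine with two dimethylamino chains widens to a number 33.3 percentage points higher from compound 1 to compound 4 (beyond the scatter) in this assay.

Going by these compounds, the ring and the chain change together, so it remains open which one accounts for the step, and how a morpholin-4-yl group would read on this aromatic carbon. Nothing available here explains these differences.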